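The compounds below may be only part of what the source reports. "The series", "measured", "known", "first", "only" and "open" are said of these compounds alone.

Compound 2 `CCCCC(=O)c1ccc(C(CC)(CC)c2ccc(C#CC(O)(CC)CC)c(C)c2)n1CC` is one of two measured members of a shared core. In an assay on cells for agonist activity at vitamin D3 receptor (Homo sapiens), read by microscopy (a lower number here means that less compound is needed, a higher number that more compound is needed for the effect), compound 2 gives > 50 nM, which is a limit of the assay rather than a number. Compound 1 `CCn1c(C(=O)On2nnc3ccccc32)ccc1C(CC)(CC)c1ccc(C#CC(O)(CC)CC)c(C)c1` carries a much larger group on the carbonyl carbon. In this assay compound 1 gives > 50 nM, also a limit. Between these two compounds lies a step that the two limits leave unreadable from compound 1 to compound 2, since (the limit of > 50 nM in this assay, at which 2 of the 2 values shown sit). Compound 3 `CCn1c(C(=O)NCCCO)ccc1C(CC)(CC)c1ccc(C#CC(O)(CC)CC)c(C)c1` has not yet been measured. It differs from compound 2 in one place: (3-hydroxypropyl)amino in place of butyl on a carbonyl carbon. Among the measured compounds shown here, no measured step gives readable guidance on this change; the only one available is itself unreadable, as both of its values sit at the limit. The expectation for compound 3 therefore rests on compound 2 alone, whose value is only a limit, so neither the direction nor the size of the change can be read from the data. The step is estimated as a step that the limit leaves unreadable from compound 2 to compound 3, with no basis for a clear shift. The estimate for compound 3 is 100 nM, within a range from 20 nM to 1000 nM.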

Compound 3, half-maximal effective concentration: 137 nM
Compound 3: middle estimate off by 1.4-fold (0.14 log units), on the low side; measured number inside the range.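

Compound 3 now has a measured number in this assay, but compound 1 and compound 2 each stand only at a limit, so no step from either of them to compound 3 can be read: the limit of > 50 nM in this assay, at which 2 of the 3 values shown sit.

From the compounds shown here alone, it remains open whether (3-hydroxypropyl)amino in place of butyl on a carbonyl carbon changes the amount of compound needed, and in which direction.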